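Swapping the aryl arm for a propyl chain

A few compounds are considered here, and "the series" means these few. Any claim that something is new, unique, unknown or untested is made for them only; others in the source may bear on it.

Compound 1, `CC(=O)OC[C@H]1O[C@@H](n2cc(CN3C(=O)/C(=C/c4ccc(C)cc4)c4ccccc43)nn2)[C@H](OC(C)=O)[C@@H](OC(C)=O)[C@@H]1OC(C)=O`, was tested in a functional assay on MCF7 cells (Homo sapiens) for cytotoxicity, read by sulforhodamine B assay, with a stated time of 48 h; a higher number here means a weaker inhibitor, a lower number a stronger inhibitor. In this assay compound 1 stops at the limit of > 100000 nM, a bound rather than a number. Compound 2, `CC(=O)OC[C@H]1O[C@@H](n2cc(CN3C(=O)/C(=C\c4ccc(C)cc4)c4ccccc43)nn2)[C@H](OC(C)=O)[C@@H](OC(C)=O)[C@@H]1OC(C)=O`, has the same atoms and bonds with the double bond drawn the other way. In this assay compound 2 also stops at the limit of > 100000 nM. The step that the two limits leave unreadable from compound 1 to compound 2 cannot be read because of the limit of > 100000 nM in this assay, at which 2 of the 3 values shown sit. Among the measured compounds shown here, compound 3, `CC(=O)OC[C@H]1O[C@@H](n2cc(CN3C(=O)/C(=C\c4ccco4)c4ccccc43)nn2)[C@H](OC(C)=O)[C@@H](OC(C)=O)[C@@H]1OC(C)=O`, carries a furan-2-yl in place of the 4-methylphenyl, and in this assay compound 3 gives 38200 nM; the step of an at least 2.6-fold lower number from compound 2 to compound 3 (0.41 log units; beyond the scatter) is the only readable change among the three. The unmeasured compound 4, `CCC/C=C1/C(=O)N(Cc2cn([C@@H]3O[C@H](COC(C)=O)[C@@H](OC(C)=O)[C@H](OC(C)=O)[C@H]3OC(C)=O)nn2)c2ccccc21`, alters the same place differently: propyl in place of 4-methylphenyl on a double-bonded chain carbon bound to a double-bonded ring carbon. For the measured compounds named here, no measured step shows a chain replacing the ring there, the one readable step moved the number only modestly, and compound 1 itself is known only as a limit. For compound 4 the step of a number no higher from compound 1 to compound 4 (the limit leaves the size open) is therefore expected to be small or unreadable. Compound 4 is estimated at 100000 nM, within 30000 nM to 300000 nM.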

Compound 4, half-maximal inhibitory concentration: 22600 nM
The estimate for compound 4 lay 4.4-fold (0.65 log units) above the measured number; the measured number lies below the stated range.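

In this assay, propyl in place of 4-methylphenyl gives an at least 4.4-fold lower number from compound 1 to compound 4 (0.64 log units; beyond the scatter), so an aromatic ring is not needed on this double-bonded chain carbon for a readable value. Among the compounds shown here, until now, the only readable value came from compound 3, which still carries a ring there, furan-2-yl, whereas compound 4 gives one with an open chain of fewer heavy atoms. The full size of this step stays open, and the step between the two drawn forms of the double bond cannot be read, because each rests on a limit: the limit of > 100000 nM in this assay, at which 2 of the 4 values shown sit.

As far as these compounds go, whether a longer chain, or a chain ending in an amine or a carboxylic acid, would move the number further remains open. Also open, from the compounds shown here alone, is whether the propyl compound with its double bond drawn the other way would give a different number.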